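A few compounds are considered here, and "the series" means these few. Any claim that something is new, unique, unknown or untested is made for them only; others in the source may bear on it.

Measured so far:
Compound 1 `O=C(O)Cn1c(=O)c(/C=C/c2ccc(O)c(O)c2)nc2cc(Cl)cnc21`: 97.1%
Compound 3 `COc1cc(/C=C/c2nc3cc(Cl)cnc3n(CC(=O)O)c2=O)ccc1O`: 94.9%
Compound 2 `COc1cc(O)cc(-c2nc3cccnc3n(CC(=O)O)c2=O)c1`: "not determined" (no result reported)

In a functional assay, read by spectrophotometry, with a stated time of 30 min, tested at 100 uM (a lower number here means a weaker effect, a higher number a stronger effect of the compound at the concentration tested), compound 1 gives 97.1%, the highest of the two numbers; the nearest is compound 3, with a number 2.2 percentage points lower from compound 1 to compound 3 (within the scatter), a change of methyl in place of hydrogen on an oxygen on an aromatic ring. Compound 4 `O=C(O)Cn1c(=O)c(/C=C/c2ccc(O)c(O)c2)nc2cc(Br)cnc21` has not been measured in this assay. It differs from compound 1 by bromo in place of chloro on an aromatic carbon. For the measured compounds named here, no measured step swaps one halogen for another, so the only step on record, a number 2.2 percentage points lower from compound 1 to compound 3 (within the scatter), bears on it just loosely, and it was within the scatter. A step of similar size is therefore expected, a number 2.1 percentage points lower from compound 1 to compound 4 (within the scatter). Compound 4 is estimated at 95%, between 85% and 100%.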

Compound 4, a percentage reported as activity, at one concentration (the size of the read-out at that concentration, not a potency): 95.8%
For compound 4 the middle estimate is 0.8 percentage points below the measured one; the range from low to high includes it.
By their numbers in this assay, from the lowest: compounds 3, 4 and 1 (each within the scatter of the next).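

In this assay, bromo in place of chloro on the aromatic carbon gives a number 1.3 percentage points lower from compound 1 to compound 4 (within the scatter), so this read-out does not tell the two halogens apart at this position. For the compounds shown here, this is the first look at that part of the molecule, since the earlier step concerned only a methyl on an oxygen on an aromatic ring. Nothing available accounts for the result of this swap. The compounds shown leave open how an amine or a nitrile would read on this carbon, and whether a halogen is needed there at all. A read-out at a single concentration also cannot show whether compound 1 and compound 4 differ in potency.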